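The source may report more compounds than this note shows. Statements on the series, on what has been measured and on what is new or still open speak of the compounds shown alone.

For the measured compounds named here, compound 2, `CC(C)C(c1ccccc1)c1nc2c(C(F)(F)F)cccc2c(C(=O)O)c1O`, is the higher of the two numbers measured so far in an assay on isolated protein for inhibition of P-selectin glycoprotein ligand 1 (Homo sapiens), read by surface plasmon resonance, tested at 250 uM; a lower number here means less inhibition, a higher number more inhibition at the concentration tested (going by the name of the read-out); in this assay compound 2 gives 58%. Its nearest neighbour is compound 1, `CC(c1ccccc1)c1nc2c(C(F)(F)F)cccc2c(C(=O)O)c1O`, which in this assay gives 50%. Going by the values given here, the one step measured between them, isopropyl in place of methyl on a saturated chain carbon bound to two aromatic carbons, is a number 8 percentage points higher from compound 1 to compound 2 (within the scatter), so the two compounds cannot be ordered on these numbers.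

Compound 3, `CC(C)C(c1ccc(Cl)cc1)c1nc2c(C(F)(F)F)cccc2c(C(=O)O)c1O`, differs from compound 2 at a single place: chloro in place of hydrogen on an aromatic carbon. Viewed one bond further out, this reads as phenyl to 4-chlorophenyl. Among the compounds with values here, no measured step touches the phenyl ring, so nothing among the known compounds speaks directly to this change. Within the data shown here, the only measured step, a number 8 percentage points higher from compound 1 to compound 2 (within the scatter), concerns a different part of the molecule and was itself within the scatter. On that basis no movement beyond the scatter is expected, and the estimated step is a number 2 percentage points higher from compound 2 to compound 3 (within the scatter). Compound 3 is therefore expected to give about 60% in this assay, in a range from 40% to 78%.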

Compound 3, a percentage reported as inhibition, at one concentration (the size of the read-out at that concentration, not a potency): <= 10%
Compound 3: no number, only a limit; the forecaster's own chance of this, stated with the estimate: 2%; middle value at least 50 percentage points from the limit.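

For the compounds shown here, the phenyl ring, which no earlier step had touched, proves to be a place where this assay responds strongly: chloro in place of hydrogen on an aromatic carbon, para to a large group, is a number at least 48 percentage points lower from compound 2 to compound 3 (beyond the scatter). For compound 3, the value of <= 10% is a limit of the assay and not a number. The only earlier step, isopropyl in place of methyl, stayed within the scatter, so this single added chlorine is the first change among the compounds shown to move the read-out beyond it, and the full size of the drop remains unfixed: the limit of <= 10% in this assay, at which 1 of the 3 values shown sits.

The compounds shown leave open whether the loss is particular to chloro or would also follow from another group at the same place, such as fluoro, methyl or methoxy, and whether chloro on another carbon of the ring would act in the same way. They also leave open whether 4-chlorophenyl would give a similar result with methyl rather than isopropyl on the chain carbon, and they give no measured property that could explain the change.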